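Swapping the Ethylamino Group of Compound 2

The source may report more compounds than this note shows. Statements on the series, on what has been measured and on what is new or still open speak of the compounds shown alone.

In a functional assay on the whole organism for positive allosteric modulation, with Mus musculus as the target (a lower number here means that less compound is needed, a higher number that more compound is needed for the effect), compound 1 (`CCC(=O)N(c1ccc([N+](=O)[O-])cc1)C1CCCC1N(C)C`) gives 20 mg/kg, while compound 2 (`CCNC1CCCC1N(C(=O)CC)c1ccc(Cl)c(Cl)c1`) gives 0.2 mg/kg. Compound 2 therefore holds the lower of the two numbers, and the gap lies well beyond the usual scatter of repeated measurements. The two compounds differ in more than one place, so their gap cannot be tied to any single change.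

Compound 3 (`CCC(=O)N(c1ccc(Cl)c(Cl)c1)C1CCCC1N(C)CCN(C)C`) keeps the rest of compound 2 but carries (2-(dimethylamino)ethyl)(methyl)amino in place of ethylamino on a saturated ring carbon. For the measured compounds named here, no measured pair shows this change on its own, so any forecast is uncertain. Going by the values given here, with compound 2 at 0.2 mg/kg, the lowest number so far, and with a much larger group entering, a rise seems more likely than a further fall. The expected change is a 10-fold higher number from compound 2 to compound 3 (1.00 log units; beyond the scatter), toward a higher dose in this assay and beyond the scatter. Compound 3 is estimated at 2 mg/kg, with an expected range of 0.3 mg/kg to 15 mg/kg.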

Compound 3, dose for half-maximal effect: 0.8 mg/kg
The estimate for compound 3 lay 2.5-fold (0.40 log units) above the measured number; the measured number falls inside the stated range.
By their numbers in this assay, from the lowest: compound 2; then compound 3; then compound 1.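

In this assay, for the compounds shown here, this is the first reading of a single change at this position: putting (2-(dimethylamino)ethyl)(methyl)amino in place of ethylamino on a saturated ring carbon gives a 4.0-fold higher number from compound 2 to compound 3 (0.60 log units; beyond the scatter), so the smaller group keeps the lower number. The step is modest for such a swap, with 7 heavy atoms entering where 3 leave, and with 0 hydrogen-bond donors and 2 hydrogen-bond acceptors entering where 1 of each leaves, yet compound 3 still gives 0.8 mg/kg. Nothing measured here explains what lies behind this step.

The swap alters the heavy-atom count, the donor count, and the acceptor count together, so this one step cannot assign the rise in dose to any one of these differences. A propylamino group at the same position would add length while keeping an amine hydrogen, and a 2-(dimethylamino)ethylamino group would keep that hydrogen alongside the second nitrogen, so the two would help separate these differences.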